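Swapping a Furan for a Saturated Ring in a Urea Series

The source may hold more compounds than are shown below. What is called first, only, known or untested is meant among the compounds shown, and "the series" means these compounds.

Measured so far:
Compound 1, `O=C(Nc1ccc(OC(F)(F)F)cc1)NC1CCN(C(=O)c2ccoc2)CC1`: 7.6 ug/mL
Compound 2, `O=C(Nc1ccc(C(F)(F)F)cc1)NC1CCN(C(=O)c2ccoc2)CC1`: 2.2 ug/mL
Compound 3, `O=C(Nc1ccc(OC(F)(F)F)c(F)c1)NC1CCN(C(=O)C2CC2)CC1`: 19 ug/mL

Of the compounds shown here, three have been measured in a physicochemical assay for solubility, read by mass spectrometry, in phosphate buffer, with a stated time of 24 h, at pH 7.4; a lower number here means a less soluble compound, a higher number a more soluble compound. Compound 2 gives the lowest of the three numbers, 2.2 ug/mL. For the measured compounds named here, its nearest neighbour is compound 1, and the one single-point step measured reads a 3.5-fold lower number from compound 1 to compound 2 (0.54 log units; beyond the scatter). Compound 3 gives 19 ug/mL, the highest of the three, but it differs from compound 2 in more than one place, so only the two numbers themselves can be set side by side.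

Compound 4, `O=C(Nc1ccc(C(F)(F)F)cc1)NC1CCN(C(=O)C2CCCOC2)CC1`, has not been measured. It differs from compound 2 in one place: oxan-3-yl in place of furan-3-yl on a carbonyl carbon. Going by the values given here, no measured step shows this exchange; the single step on record, a 3.5-fold lower number from compound 1 to compound 2 (0.54 log units; beyond the scatter), alters a different part of the molecule and gives no direct guide. In this assay a modest rise from compound 2 is expected, a 2.3-fold higher number from compound 2 to compound 4 (0.36 log units; beyond the scatter), with wide uncertainty. The estimate for compound 4 is 5 ug/mL, expected to fall between 1.5 ug/mL and 15 ug/mL.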

Compound 4, solubility: 1.1 ug/mL
Beside the measured number, compound 4's estimate is 4.5-fold (0.66 log units) above it, and the stated range ends above it.
By their numbers in this assay, from the lowest: compounds 4 and 2 (each within the scatter of the next); then compound 1; then compound 3.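

For the compounds shown here, this is the first look at the group on the carbonyl carbon with the rest of the molecule held fixed, since the only earlier step changed a different part of the structure. In this assay, oxan-3-yl in place of furan-3-yl reads a 2.0-fold lower number from compound 2 to compound 4 (0.30 log units; within the scatter), so a five-membered aromatic ring and a six-membered non-aromatic ring, each with one oxygen and one hydrogen-bond acceptor, cannot be told apart here. No supporting measurement bears on why this exchange gives such a result.

As far as these compounds go, whether an amine or a carboxylic acid on the ring at this carbonyl would move the number beyond the scatter remains open. So does whether the same ring exchange would read alike with trifluoromethoxy in place of trifluoromethyl on the aromatic carbon.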